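The source may hold more compounds than are shown below. What is called first, only, known or untested is meant among the compounds shown, and "the series" means these compounds.

Compound 2 `Cn1cncc1C1CCCc2c(NS(C)(=O)=O)cccc21` stands at the limit of an assay on isolated protein (Cricetulus griseus) for binding affinity to Alpha-1B adrenergic receptor (Mesocricetus auratus), read by radioligand binding; on this read-out lower numbers stand for stronger inhibition and higher numbers for weaker inhibition: in this assay compound 2 gives < 10000 nM, a limit and not a number. Compound 1 `Cn1cnc(C2CCCc3c(NS(C)(=O)=O)cccc32)c1` gives 2040 nM in this assay. Compound 3 `CCS(=O)(=O)Nc1cccc2c1CCCC2CN` gives < 10000 nM in this assay, again a limit. The step that the limit leaves unreadable from compound 1 to compound 2 is therefore unreadable; see (the limit of < 10000 nM in this assay, at which 2 of the 3 values shown sit). Compound 4 `CS(=O)(=O)Nc1cccc2c1CCCC2C1=NCCN1` differs from compound 2 by a group of 5 heavy atoms (3 carbon, 2 nitrogen; one five-membered non-aromatic ring with 2 hetero atoms) in place of a group of 6 heavy atoms (4 carbon, 2 nitrogen; one five-membered aromatic ring with 2 hetero atoms), on a saturated ring carbon. Within the data shown here, no measured step covers this change, and the only step at the same saturated ring carbon cannot be read. Among the measured compounds shown here, the expectation for compound 4 therefore rests loosely on the one readable number, that of compound 1 at 2040 nM. Compound 4 is expected at 1500 nM in this assay, with a range from 150 nM to 9000 nM. The step expected thereby is a step that the limit leaves unreadable from compound 2 to compound 4, a direction a limit cannot fix.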

Compound 4, inhibition constant: 7410 nM
For compound 4 the middle estimate is 4.9-fold (0.69 log units) below the measured one; low and high end bracket the measured number.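

In this assay, the saturated ring carbon now has its first readable step: a 3.6-fold higher number from compound 1 to compound 4 (0.56 log units; beyond the scatter), with the five-membered non-aromatic ring entering in place of 1-methyl-1H-imidazol-4-yl. A non-aromatic group at this carbon thus still gives a readable number, though a modestly higher one than the aromatic group of compound 1. The steps from compound 1 to compound 2 and from compound 2 to compound 4 cannot be read: the limit of < 10000 nM in this assay, at which 2 of the 4 values shown sit.

On these data alone, the order of compound 2 and compound 4 stays open. As far as these compounds go, how a carboxylic acid or a phenyl ring at this saturated ring carbon would read in this assay also stays open.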